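Indole attachment point shift on the shared cyclobutenedione core

The source may report more compounds than this note shows. Statements on the series, on what has been measured and on what is new or still open speak of the compounds shown alone.

Measured so far:
Compound 1, `COc1cc(-c2c(-c3ccc4cc[nH]c4c3)c(=O)c2=O)cc(OC)c1OC`; in a functional assay on CCRF-CEM cells (Homo sapiens) for inhibition, read by MTT assay, with a stated time of 72 h (a lower number here means a stronger inhibitor, a higher number a weaker inhibitor), compound 1 gives 6.6 nM.
Compound 2, `COc1ccc(-c2c(-c3cc(OC)c(OC)c(OC)c3)c(=O)c2=O)cc1OC`; in this assay compound 2 gives 210 nM.
Compound 3, `COc1ccc(-c2c(-c3ccc(OC)c(OC)c3OC)c(=O)c2=O)cc1`; in this assay compound 3 gives 2480 nM.

Compound 1 holds the lowest number of the three in this assay. Compound 2 is its nearest neighbour, and that gap lies beyond the scatter; compound 3 is furthest, and that gap also lies beyond the scatter. Among the measured compounds shown here, no two measured compounds differ in one place only, so no step size between measured compounds is at hand to calibrate against.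

Compound 4, `COc1cc(-c2c(-c3ccc4[nH]ccc4c3)c(=O)c2=O)cc(OC)c1OC`, is not yet measured. Relative to compound 1 the change is 1H-indol-5-yl in place of 1H-indol-6-yl on an aromatic carbon; the two compounds hold the same atoms, joined differently, and the shared core with its trimethoxyphenyl ring is untouched. For the measured compounds named here, nothing among the measured compounds speaks to a move of this kind, so the direction is uncertain. The step from compound 1 to compound 4 is expected to be small, a 2.3-fold higher number from compound 1 to compound 4 (0.36 log units; beyond the scatter), at most a mild weakening and possibly none beyond the scatter. Compound 4 is therefore estimated at 15 nM in this assay, within a range from 3 nM to 80 nM.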

Compound 4, half-maximal inhibitory concentration: 15.4 nM
Beside the measured number, compound 4's estimate is 1.0-fold (0.01 log units) below it; the range from low to high includes it.
By their numbers in this assay, from the lowest: compound 1; then compound 4; then compound 2; then compound 3.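

Among the compounds shown here, the move from 1H-indol-6-yl to 1H-indol-5-yl is the first change made in one place only, so it gives the first step size at this position: in this assay the result is a 2.3-fold higher number from compound 1 to compound 4 (0.37 log units; beyond the scatter). The step is modest yet beyond the scatter, so the attachment point of the indole on the shared core does register in the read-out, though compound 4 still gives 15.4 nM and the ring pair, its atoms and its hydrogen-bond donor count are all unchanged. No measurement at hand accounts for the lower number with the 1H-indol-6-yl group.

The compounds shown cover only two attachment points of the indole, so it remains open whether any other attachment point would give a smaller or larger step, and whether the direction seen here would hold on a different core. Also open, as far as these compounds go, is what a methyl group on the indole nitrogen, or a carboxylic acid or a dimethylamino chain on the indole, would do to the number in this assay when the trimethoxyphenyl ring is held fixed.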